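The compounds below may be only part of what the source reports. "The series", "measured", "known", "first", "only" and "open" are said of these compounds alone.

Three compounds of this series have been run in an ADME assay on cells (Splenocyte, Mus musculus, strain BALB/c) for cytotoxicity, read by MTT assay, tested at 1 ug/mL; on this read-out higher numbers stand for a stronger effect at the one concentration tested and lower numbers for a weaker effect. Compound 1 `CCCCCCCCCCCCCCC(N)COCc1ccccc1` gives 0% in this assay. Compound 2 `CCCCCCCCCCCCCCC(COCc1ccccc1)N(CC)CC` gives 14.1% in this assay. Compound 3 `CCCCCCCCCCCCCCC(CN)NC(=O)OC(C)(C)C` gives 4.2% in this assay. Compound 4 `CCCCCCCCCCCCCCC(CN(CC)CC)NC(=O)OC(C)(C)C` has not yet been run in this assay.

For the measured compounds named here, the one paired step among the measured compounds is a number 14.1 percentage points higher from compound 1 to compound 2 (beyond the scatter). The change behind it is diethylamino in place of amino on a saturated chain carbon bound to two saturated chain carbons. Compound 3 set against compound 1 shows only a gap within the scatter, and the difference between the two cores is not broken down here. Compound 3 set against compound 2 likewise shows only a gap within the scatter.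

Compound 4 differs from compound 3 by diethylamino in place of amino on a saturated chain carbon, two bonds along the chain from an amide-type nitrogen. Going by the values given here, this is the same kind of change as the one from compound 1 to compound 2, not the same change: in compound 1 the carbon that carries the group is bound to two saturated chain carbons, whereas in compound 3 it is two bonds along the chain from an amide-type nitrogen. Among the compounds with values here, the expected step in this assay is a number 11.8 percentage points higher from compound 3 to compound 4 (beyond the scatter), set beside the earlier step of a number 14.1 percentage points higher from compound 1 to compound 2 (beyond the scatter) as the only measured instance of this kind of change. With a single pair behind it the expectation is loose and the range is kept wide. Compound 4 is expected to give 16%, between 4% and 30%.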

Compound 4, a percentage reported as activity, at one concentration (the size of the read-out at that concentration, not a potency): 6.5%
Beside the measured number, compound 4's estimate is 9.5 percentage points above it; the measured number falls inside the stated range.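

In this assay, diethylamino in place of amino on a saturated chain carbon, two bonds along the chain from an amide-type nitrogen, gives a number 2.3 percentage points higher from compound 3 to compound 4 (within the scatter), so on this core the change leaves a gap that cannot be told from repeat scatter, while the earlier step on the other core stands clear of it. Set side by side, the two steps cannot be told apart either: the same change on two cores in this assay, a number 14.1 percentage points higher (beyond the scatter) from compound 1 to compound 2 and a number 2.3 percentage points higher (within the scatter) from compound 3 to compound 4, 11.8 percentage points apart, within the scatter of two such steps. For the compounds shown here, this shows that nothing here separates the behaviour of the change on the two cores, but it does not show that the change carries over intact, nor that the core dampens it, since each core offers a single pair read at one concentration, and only one of the two steps stands beyond the scatter.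

As far as these compounds go, what a dimethylamino group or a carboxylic acid would give in place of diethylamino on either core remains open, and a further pair of this kind would be needed to tell whether the two steps really differ. Also open, from the compounds shown here alone, is whether a shorter chain in place of the long saturated chain would leave these small read-outs as they stand.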